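Ethoxy in place of methoxy on the core of compound 3

The source may report more compounds than this note shows. Statements on the series, on what has been measured and on what is new or still open speak of the compounds shown alone.

Within the data shown here, compound 3, `COc1ccn2cc(-c3ccc(NC(=O)Nc4cc(C(C)(C)C)on4)cc3)nc2c1`, gives 2.84 nM in a functional assay on MV4-11 cells (Homo sapiens) for cytotoxicity, read by MTT assay, with a stated time of 72 h (a higher number here means a weaker inhibitor, a lower number a stronger inhibitor), the lowest of the three numbers measured so far. Compound 1, `CC(C)(C)c1cc(NC(=O)Nc2ccc(-c3cn4ccccc4n3)cc2)no1`, gives 3.09 nM in this assay, and the step of a 1.1-fold lower number from compound 1 to compound 3 (0.04 log units; within the scatter) lies within the scatter, so no order between these two can be claimed. Compound 2, `CC(C)(C)c1cc(NC(=O)Nc2ccc(-c3cn4ccc(Cl)cc4n3)cc2)no1`, gives 5.91 nM in this assay; the step of a 2.1-fold lower number from compound 2 to compound 3 (0.32 log units; beyond the scatter) is modest but beyond the scatter, while the step of a 1.9-fold higher number from compound 1 to compound 2 (0.28 log units; within the scatter) stays within it.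

Compound 4, `CCOc1ccn2cc(-c3ccc(NC(=O)Nc4cc(C(C)(C)C)on4)cc3)nc2c1`, differs from compound 3 by methyl in place of hydrogen on a saturated chain carbon bound to an oxygen on an aromatic ring. Among the measured compounds shown here, none of the measured steps lengthens this chain; the nearest guides are the two steps that exchange the group on an aromatic carbon, a 1.1-fold lower number from compound 1 to compound 3 (0.04 log units; within the scatter) and a 2.1-fold lower number from compound 2 to compound 3 (0.32 log units; beyond the scatter), both small, showing that hydrogen, chloro and methoxy there move this assay little. One added carbon on the chain is therefore expected to give a step within the scatter, a 1.1-fold higher number from compound 3 to compound 4 (0.05 log units; within the scatter). Compound 4 is expected to give 3.2 nM in this assay, between 1.5 nM and 7 nM.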

Compound 4, half-maximal inhibitory concentration: 11.6 nM
Estimate against measurement, compound 4: 3.6-fold (0.56 log units) below, outside the stated range (above it).
By their numbers in this assay, from the lowest: compounds 3, 1, 2 and 4 (each within the scatter of the next, the first and the last beyond it).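

On the core, exchanging hydrogen, chloro and methoxy had moved the number little, but methyl in place of hydrogen on the saturated chain carbon bound to an oxygen on an aromatic ring gives a 4.1-fold higher number from compound 3 to compound 4 (0.61 log units; beyond the scatter) in this assay, so methoxy to ethoxy is not a neutral change here. Ethoxy also stands apart from hydrogen, with a 3.8-fold higher number from compound 1 to compound 4 (0.57 log units; beyond the scatter), whereas a 2.0-fold higher number from compound 2 to compound 4 (0.29 log units; within the scatter) stays within the scatter, so ethoxy and chloro cannot be ordered in this assay. Nothing shown here explains the effect of the added methyl.

From the compounds shown here alone, whether the number keeps rising with a longer chain such as propoxy, or with a branched isopropoxy group, stays open. Going by these compounds, it is also open whether an amine on the same aromatic carbon would behave like methoxy or like ethoxy.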